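This account rests on a few compounds, and the source may have more. Where it says the series, first, only, none or still open, it means among the compounds named here.

Compound 2 `CC1(C)Oc2ccc(C(=O)c3ccccc3)cc2[C@@H](/N=C(\NC#N)Nc2ccc(Cl)cc2)[C@@H]1O` gives the highest number of the three compounds measured in a functional assay (aorta) with Rattus norvegicus as the target (on this read-out lower numbers stand for stronger inhibition and higher numbers for weaker inhibition), at 7100 nM. Compound 1 `CC1(C)Oc2ccc(C#N)cc2[C@@H](/N=C(\NC#N)Nc2ccc(Cl)cc2)[C@@H]1O` gives 1800 nM, and compound 3 `CC1(C)Oc2ccc(S(=O)(=O)Nc3ccccc3)cc2[C@@H](/N=C(\NC#N)Nc2ccc(Cl)cc2)[C@@H]1O` gives 3300 nM in this assay. Compound 4 `C[C@@H]1CCC[C@H](C)N1S(=O)(=O)c1ccc2c(c1)[C@@H](/N=C(\NC#N)Nc1ccc(Cl)cc1)[C@H](O)C(C)(C)O2` awaits measurement. Its change from compound 2 is (2,6-dimethylpiperidin-1-yl)sulfonyl in place of benzoyl on an aromatic carbon. Earlier steps at this position are a 3.9-fold higher number from compound 1 to compound 2 (0.60 log units; beyond the scatter), a 1.8-fold higher number from compound 1 to compound 3 (0.26 log units; within the scatter) and a 2.2-fold lower number from compound 2 to compound 3 (0.33 log units; beyond the scatter). The entering group, like the phenylsulfamoyl of compound 3, carries a sulfonyl, so a modest fall in the number is expected because a 2.2-fold lower number from compound 2 to compound 3 (0.33 log units; beyond the scatter) went that way, giving an expected step of a 2.0-fold lower number from compound 2 to compound 4 (0.31 log units; beyond the scatter). The estimate for compound 4 is 3500 nM, with a range from 1200 nM to 10000 nM.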

Compound 4, half-maximal inhibitory concentration: 500 nM
Estimate against measurement, compound 4: 7.0-fold (0.85 log units) above; measured number outside the range, below it.
By their numbers in this assay, from the lowest: compound 4; then compounds 1 and 3 (each within the scatter of the next); then compound 2.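

At this position, the group on the sulfonyl sulfur matters and not the sulfonyl alone: with the sulfonyl kept, the swap of anilino for 2,6-dimethylpiperidin-1-yl gives a 6.6-fold lower number from compound 3 to compound 4 (0.82 log units; beyond the scatter) in this assay on its own. Replacing the nitrile gives a 3.6-fold lower number from compound 1 to compound 4 (0.56 log units; beyond the scatter) and so shows that this position can go below the nitrile compound, while replacing benzoyl gives a 14-fold lower number from compound 2 to compound 4 (1.15 log units; beyond the scatter) as the largest step seen here. No measurement at hand explains this change. As far as these compounds go, whether the two methyl groups are needed stays open, and a plain piperidin-1-yl or a morpholin-4-yl on the sulfonyl would test it.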